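The source may hold more compounds than are shown below. What is called first, only, known or untested is meant among the compounds shown, and "the series" means these compounds.

Measured compounds:
- compound 1, `Cc1nc2c3ccccc3ccc2c2nc3c(ccc4ccccc43)c(-c3cccc4ccccc34)c12`, 20800 nM
- compound 2, `Cc1nc2c3ccccc3ccc2c2nc3c(ccc4ccccc43)c(-c3ccc(O)cc3)c12`, 3190 nM

In a functional assay on HCT-116 cells (Homo sapiens) for cytotoxicity, read by MTT assay, with a stated time of 48 h (on this read-out lower numbers stand for stronger inhibition and higher numbers for weaker inhibition), compound 2 gives the lower of the two numbers recorded so far. For the measured compounds named here, the step from it to its only neighbour is a 6.5-fold lower number from compound 1 to compound 2 (0.81 log units; beyond the scatter), so compound 1 stands clearly apart, and compound 2 is the better of the two within the set.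

Compound 3, `Cc1nc2c3ccccc3ccc2c2nc3c(ccc4ccccc43)c(-c3cc(O)nc4ccccc34)c12`, has not yet been measured. It differs from compound 2 in one place: 2-hydroxyquinolin-4-yl in place of 4-hydroxyphenyl on an aromatic carbon. Going by the values given here, the only step measured bears on it at most indirectly. That step, a 6.5-fold lower number from compound 1 to compound 2 (0.81 log units; beyond the scatter), shows that replacing a bicyclic group by a hydroxyl-bearing phenyl moved the number down markedly. Among the compounds with values here, the group entering in compound 3 is again bicyclic but keeps a hydroxyl, so the two features of that earlier step pull in opposite directions, and no measured pair isolates either one. The expected change is therefore small, a 1.3-fold higher number from compound 2 to compound 3 (0.10 log units; within the scatter), with considerable uncertainty in both directions. Compound 3 is estimated at 4000 nM in this assay, within a range of 1200 nM to 14000 nM.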

Compound 3, half-maximal inhibitory concentration: 4630 nM
Estimate against measurement, compound 3: 1.2-fold (0.06 log units) below; the range from low to high includes it.
By their numbers in this assay, from the lowest: compounds 2 and 3 (each within the scatter of the next); then compound 1.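

In this assay this place, opposite the ring nitrogen, takes the 2-hydroxyquinolin-4-yl group with its larger count of heavy atoms, and a 1.5-fold higher number from compound 2 to compound 3 (0.16 log units; within the scatter) leaves that group and 4-hydroxyphenyl indistinguishable on this read-out. The second step, a 4.5-fold lower number from compound 1 to compound 3 (0.65 log units; beyond the scatter), adds what the earlier pair could not show: two bicyclic groups at the same place can differ beyond the scatter, so a second fused ring does not by itself give the number of compound 1, and among these three compounds the two carrying a hydroxyl group sit together, with compound 1, which has none, apart. The data offer no independent measurement that would explain either step.

The compounds shown do not separate the hydroxyl group from the ring nitrogen of the quinoline, as 2-hydroxyquinolin-4-yl differs from naphthalen-1-yl in both at once. They also leave open whether an amine or a carboxylic acid in place of the hydroxyl group on the phenyl ring would keep the number near those of compound 2 and compound 3, or return it towards that of compound 1.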